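The compounds below may be only part of what the source reports. "The series", "measured", "known", "first", "only" and "open" are said of these compounds alone.

Two measured compounds sit on the same core, a ketone-linked chain carrying a phenyl-substituted phenyl group at one end and a five-membered aromatic ring bearing a pyridine at the other. Compound 1 `O=C(O)c1ccc(-c2cnc(C(=O)CCc3ccc(-c4ccccc4)cc3)o2)cn1` gives 44 nM in an assay for inhibition of Fatty-acid amide hydrolase 1 (Rattus norvegicus); a lower number here means a stronger inhibitor, a higher number a weaker inhibitor. Compound 2 `O=C(O)c1ccc(-c2cnc(CCCc3ccc(-c4ccccc4)cc3)o2)nc1` lacks the ketone and carries its pyridine acid differently; in this assay compound 2 gives 20000 nM. Of the two numbers, compound 1 has the lower one, and the gap to compound 2 is far beyond the usual scatter, so compound 1 is clearly the stronger inhibitor of this pair.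

Compound 3 `COC(=O)c1cccc(-c2cnc(C(=O)CCc3ccc(-c4ccccc4)cc3)o2)n1` keeps the ketone of compound 1 and changes only the pyridine: 6-(methoxycarbonyl)pyridin-2-yl in place of 6-carboxypyridin-3-yl on an aromatic carbon. The free acid is thereby capped as a methyl ester and the pyridine is attached through a different ring carbon. Going by the values given here, with no measured step of this kind to lean on, the expectation can rest only on the fact that the ketone, which compound 1 holds and compound 2 lacks, is retained. The ester is expected to be at least as good as the acid, and a moderate step downward, toward a stronger inhibitor, is estimated as a 5.5-fold lower number from compound 1 to compound 3 (0.74 log units; beyond the scatter). Compound 3 is therefore expected to give about 8 nM in this assay, within a range of 1.5 nM to 40 nM.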

Compound 3, inhibition constant: 1.2 nM
Compound 3: middle estimate off by 6.7-fold (0.82 log units), on the high side; measured number outside the range, below it.
By their numbers in this assay, from the lowest: compound 3; then compound 1; then compound 2.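

The group on the aromatic carbon next to the ring oxygen has a strong hold on the result: with the ketone kept, putting 6-(methoxycarbonyl)pyridin-2-yl in place of 6-carboxypyridin-3-yl gives a 37-fold lower number from compound 1 to compound 3 (1.56 log units; beyond the scatter) in this assay. A free carboxylic acid on the pyridine is therefore not required for strong inhibition on this core, since compound 3 carries a methyl ester, has no hydrogen-bond donor in this group, and still gives the lower number. No evidence is at hand on what lies behind this gain.

This single step changes two things at once, the capping of the acid and the ring carbon through which the pyridine is attached, so the gain cannot be divided between them; 6-carboxypyridin-2-yl or 6-(methoxycarbonyl)pyridin-3-yl on the same core would separate the two changes. Going by these compounds, it also remains open how far the ester itself can vary at this position, for example whether an ethyl ester or a primary amide would match the methyl ester of compound 3.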